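This account rests on a few compounds, and the source may have more. Where it says the series, first, only, none or still open, it means among the compounds named here.

Compound 3 `Cc1cccc(-n2nncc2CN2C(=O)C3(C(C#N)=C(N)Oc4c(N)cc5nc6ccccc6nc5c43)c3ccccc32)c1` is one of three compounds whose results in a functional assay on HCT-116 cells (Homo sapiens) for antiproliferative activity, read by MTT assay, with a stated time of 48 h (on this read-out higher numbers stand for weaker inhibition and lower numbers for stronger inhibition), are known. Compound 3 gives > 50000 nM, which is a limit of the assay and not a number. Compound 1 `COc1ccc(-n2nncc2CN2C(=O)C3(C(C#N)=C(N)Oc4c3c3nc5ccccc5nc3c3ccccc43)c3ccccc32)cc1` gives > 50000 nM, also a limit. Compound 2 `CCOc1ccccc1-n1nncc1CN1C(=O)C2(C(C#N)=C(N)Oc3c2c2nc4ccccc4nc2c2ccccc32)c2ccccc21` gives > 50000 nM, again a limit. The only one-point comparison among these, a step that the two limits leave unreadable from compound 1 to compound 2, therefore cannot be sized, and the limit of > 50000 nM in this assay, at which 3 of the 3 values shown sit, sums up where all three stand. Compound 4 `COc1ccccc1-n1nncc1CN1C(=O)C2(C(C#N)=C(N)Oc3c(N)cc4nc5ccccc5nc4c32)c2ccccc21` differs from compound 3 by 2-methoxyphenyl in place of 3-methylphenyl on an aromatic nitrogen. Among the compounds with values here, no measured step shows what such a change does here, so no shift beyond the scatter can be argued in either direction. Compound 4 is expected to give 60000 nM, between 15000 nM and 250000 nM, which means an estimated step that the limit leaves unreadable from compound 3 to compound 4.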

Compound 4, half-maximal inhibitory concentration: > 50000 nM
Compound 4 was reported as a limit; the forecaster's own chance of this, stated with the estimate: 80%; the middle value is on the limit's open side.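

Within the data shown here, compound 3 and compound 4 both end at a limit of the assay, so no step between them can be read. For the compounds shown, this assay leaves open how strongly any of them inhibits: the limit of > 50000 nM in this assay, at which 4 of the 4 values shown sit.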